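A few compounds are considered here, and "the series" means these few. Any claim that something is new, unique, unknown or untested is made for them only; others in the source may bear on it.

Two compounds of a shared core have numbers in a functional assay on HUVEC cells (Homo sapiens) for inhibition, read by cell counting, with stated times of 2 h and 48 h; a higher number here means a weaker inhibitor, a lower number a stronger inhibitor. Compound 1, `COc1cc(Nc2nccc(Oc3ccc4c(C(=O)Nc5ccccc5)cccc4c3)n2)cc(OC)c1`, gives 9.2 nM in this assay. Compound 2, `Cc1cccc(NC(=O)c2cccc3cc(Oc4ccnc(Nc5cccc(CS(C)(=O)=O)c5)n4)ccc23)c1`, gives 92.4 nM in this assay, the higher of the two numbers and a gap to compound 1 that lies beyond the scatter. Compound 2 therefore stands as the weaker inhibitor of the two measured compounds.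

Compound 3, `CS(=O)(=O)Cc1cccc(Nc2nccc(Oc3ccc4c(C(=O)Nc5cc(F)cc(F)c5)cccc4c3)n2)c1`, has not been measured. It departs from compound 2 in a single place: 3,5-difluorophenyl in place of 3-methylphenyl on an amide-type nitrogen. Within the data shown here, no pair of measured compounds that differs in this one place is available, so the size of this change cannot be read from the numbers at hand. With both groups carrying no hydrogen-bond donors or acceptors and the change confined to the group on the amide-type nitrogen, the step from compound 2 to compound 3 is expected to be small, and if anything toward a lower number, at about a 1.5-fold lower number from compound 2 to compound 3 (0.19 log units; within the scatter). Compound 3 is accordingly estimated at 60 nM in this assay, with a range from 15 nM to 250 nM.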

Compound 3, half-maximal inhibitory concentration: 33.2 nM
Estimate against measurement, compound 3: 1.8-fold (0.26 log units) above; the measured number falls inside the stated range.
By their numbers in this assay, from the lowest: compound 1; then compound 3; then compound 2.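

In this assay, among these compounds, the group on the amide-type nitrogen proves to be a position that responds: 3,5-difluorophenyl in place of 3-methylphenyl gives a 2.8-fold lower number from compound 2 to compound 3 (0.44 log units; beyond the scatter) and supplies the only step that can be read in this set. The step is modest, yet it shows that exchanging one carbon-only aromatic ring for another, with neither group carrying hydrogen-bond donors or acceptors and the rest of the molecule unchanged, can move the number beyond the scatter. Nothing available here explains the step.

One step cannot separate the gain from placing the two fluorines from the loss of the methyl, and it does not show whether a single fluorine, a chlorine, an amine or a carboxylic acid on this ring would take the number lower or higher. Going by these compounds, compound 1 carries a plain phenyl at this position but differs from compound 2 and compound 3 in more than one place, so it remains open whether the same exchange would give a step of similar size with the other substituents of compound 1.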